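Three measured pyridine triaryls and one still to test

A few compounds are considered here, and "the series" means these few. Any claim that something is new, unique, unknown or untested is made for them only; others in the source may bear on it.

All values below come from a functional assay on HCT-15 cells (Homo sapiens) for cytotoxicity, read by CCK-8 assay (on this read-out higher numbers stand for weaker inhibition and lower numbers for stronger inhibition), and each is a limit of the measurement rather than a number.

Compound 1, `Oc1ccccc1-c1cc(-c2cccs2)cc(-c2ccccc2O)n1`, gives > 50000 nM in this assay.
Compound 2, `Oc1cccc(-c2cc(-c3cccs3)cc(-c3ccccc3O)n2)c1`, gives > 50000 nM in this assay.
Compound 3, `Oc1cccc(-c2cc(-c3ccsc3)cc(-c3ccccc3O)n2)c1`, gives > 50000 nM in this assay.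

Compound 2 differs from compound 1 in one place: 3-hydroxyphenyl in place of 2-hydroxyphenyl on an aromatic carbon. The resulting step is a step that the two limits leave unreadable from compound 1 to compound 2. Compound 3 then differs from compound 2 by a thiophen-3-yl in place of a thiophen-2-yl, and that step is a step that the two limits leave unreadable from compound 2 to compound 3. Both steps are unreadable because of the limit of > 50000 nM in this assay, at which 3 of the 3 values shown sit.

The unmeasured compound 4, `Oc1cccc(-c2cc(-c3ccsc3)cc(-c3cccc(O)c3)n2)c1`, is to be tested in this assay. It differs from compound 3 in one place: 3-hydroxyphenyl in place of 2-hydroxyphenyl on an aromatic carbon. For the measured compounds named here, this is the same kind of change as the one from compound 1 to compound 2, though not the same: around the place, the group in compound 3 sits meta to a 3-hydroxyphenyl group and meta to a thiophen-3-yl group, whereas in compound 1 it sits meta to a 2-hydroxyphenyl group and meta to a thiophen-2-yl group. How the cores of compound 1 and compound 3 differ is not broken down here.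

For compound 4 the step from compound 3 is expected to be a step that the limit leaves unreadable from compound 3 to compound 4, resting on compound 3 giving > 50000 nM and on the earlier step of the same kind being unreadable. Compound 4 is therefore estimated at 60000 nM, most likely again only a limit.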

Compound 4, half-maximal inhibitory concentration: 1630 nM
Estimate against measurement, compound 4: 37-fold (1.57 log units) above; the measured number lies below the stated range.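

In this assay, putting 3-hydroxyphenyl in place of 2-hydroxyphenyl on this core gives an at least 30-fold lower number from compound 3 to compound 4 (1.48 log units; beyond the scatter), so on this core the change clearly strengthens inhibition. The same kind of change on the core of compound 1 cannot be compared with it, and neither that step nor the thiophene step can be read, for one shared reason: the limit of > 50000 nM in this assay, at which 3 of the 4 values shown sit. This does not show that the change carries from one core to another, nor that it fails to: the earlier step could hide a small effect, a large one or none, and the two places differ in their surroundings, with a 3-hydroxyphenyl and a thiophen-3-yl around the place in compound 3 but a 2-hydroxyphenyl and a thiophen-2-yl in compound 1.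

The compounds shown leave open whether the strong inhibition in compound 4 needs both 3-hydroxyphenyl groups alone or also the thiophen-3-yl, since no compound here pairs two 3-hydroxyphenyl groups with a thiophen-2-yl. They also leave open whether an amine or a carboxylic acid could stand in place of the hydroxyl groups on these rings.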